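Cytotoxicity notes: the step from compound 2 to compound 3

This account rests on a few compounds, and the source may have more. Where it says the series, first, only, none or still open, it means among the compounds named here.

Compound 1 `CN(Cc1ncnc2c1ncn2[C@@H]1O[C@H](CO)[C@@H](O)[C@H]1O)c1ccccc1`: 21000 nM
Compound 2 `OC[C@H]1O[C@@H](n2cnc3c(CSc4ccccc4)ncnc32)[C@H](O)[C@@H]1O`: > 100000 nM (a limit, not a number)

Both results come from a functional assay on Huh-7 cells (Homo sapiens) for cytotoxicity, read by MTT assay, with a stated time of 3 days; on this read-out lower numbers stand for higher toxicity in this test and higher numbers for lower toxicity in this test. Compound 2 gives only a limit, so it stands at the top of what the assay reports: the limit of > 100000 nM in this assay, at which 1 of the 2 values shown sits. Compound 3 `O=C(O)CSCc1ncnc2c1ncn2[C@@H]1O[C@H](CO)[C@@H](O)[C@H]1O` keeps the sulfur of compound 2 and carries carboxymethyl in place of phenyl on a sulfur.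

Within the data shown here, one measured step bears on this change, and only indirectly. It is an at least 4.7-fold higher number from compound 1 to compound 2 (0.67 log units; beyond the scatter), with phenylsulfanyl in place of methyl(phenyl)amino. Among the measured compounds shown here, that step kept the phenyl, and no measured compound here lacks it, so the data do not show what removing it does. For the measured compounds named here, with no step to point to a fall, no change beyond the scatter is expected in this assay, though a true number for compound 3 could fall lower. The expected change is a number no higher from compound 2 to compound 3 (the limit leaves the size open). Compound 3 is estimated at 100000 nM, with an expected range of 40000 nM to 200000 nM.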

Compound 3, half-maximal cytotoxic concentration: > 100000 nM
Compound 3 ended at the assay's limit; the forecaster's own chance of this, stated with the estimate: 70%; the middle value lies on the limit itself.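

In this assay compound 3 gives > 100000 nM, which is a limit and not a number. Replacing the whole side group gives an at least 4.7-fold higher number from compound 1 to compound 3 (0.67 log units; beyond the scatter), so two different sulfur-linked groups, phenylsulfanyl and (carboxymethyl)sulfanyl, now stand in place of methyl(phenyl)amino on a saturated chain carbon bound to an aromatic carbon, and the phenyl on the sulfur proves not to be required for a result at the limit. The step between the two sulfur compounds cannot be read, and no order between them can be stated, as the only thing the read-out gives for either is this ceiling: the limit of > 100000 nM in this assay, at which 2 of the 3 values shown sit.

Going by these compounds, whether an amine or a longer chain in place of carboxymethyl on this sulfur would give a number rather than a limit stays open. Also open, on these data alone, is whether the value of compound 1, 21000 nM, goes with the nitrogen of methyl(phenyl)amino or with its methyl, a question that phenylamino on the same saturated chain carbon would help to separate.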